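The compounds below may be only part of what the source reports. "The series", "measured", "known", "first", "only" and "open" are said of these compounds alone.

Measured compounds in a functional assay on HEK293 cells for agonist activity at Glucose-dependent insulinotropic receptor (Homo sapiens), read by fluorescence and cAMP accumulation, with a stated time of 30 min; a higher number here means a larger maximal response, a lower number a smaller maximal response:
- compound 1 `Cc1c(Nc2ccc(C#N)cc2Cl)ncnc1OC1C2COCC1CN(S(=O)(=O)C1CC1)C2` — 56%; 52% (2 entries)
- compound 2 `Cc1c(Nc2ccc(C#N)cc2Cl)ncnc1OC1C2COCC1CN(C(=O)OC(C)(C)C)C2` — 65%; 83% (2 entries)
- compound 3 `Cc1c(Nc2ccc(C#N)cc2Cl)ncnc1OC1C2COCC1CN(C(=O)OC1(C)CC1)C2` — 74%

Compound 1 gives the values of the several entries of compound 1 in this assay, 56%; 52% (2 entries), and compound 2 those of the several entries of compound 2 in this assay, 65%; 83% (2 entries). Compound 3 gives 74% in this assay; that is the only number shown for it, two further entries carrying no single number. Among the compounds with values here, no step between measured compounds differing in one place is available.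

Compound 4 `CC1(OC(=O)N2CC3COCC(C2)C3Oc2cc(Nc3ccc(C#N)cc3Cl)ncn2)CC1` differs from compound 3 by hydrogen in place of methyl on an aromatic carbon. Within the data shown here, with no measured step of this kind, the change from compound 3 to compound 4 is expected to stay within the usual scatter, with no clear direction. Compound 4 is therefore expected to give 68% in this assay, likely between 45% and 90%, meaning a number 6 percentage points lower from compound 3 to compound 4 (within the scatter).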

Compound 4, largest response reached (reported as percent of maximum), in percent of the reference or control that the assay uses: 88%
For compound 4 the middle estimate is 20 percentage points below the measured one, within the range that was stated.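

In this assay, within the data shown here, hydrogen in place of methyl on the aromatic carbon gives a number 14 percentage points higher from compound 3 to compound 4 (beyond the scatter), the first reading of any change at this position. In this one pair, the methyl is not needed for a large maximal response. No measurement shown here bears on why the response shifts.

As far as these compounds go, whether the same step holds with the other end groups of compound 1 and compound 2 remains open. So does the effect of a methoxy, an amine or a longer chain on this aromatic carbon.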